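Solubility Across a Benzyloxy to Methoxy Change

The source may report more compounds than this note shows. Statements on the series, on what has been measured and on what is new or still open speak of the compounds shown alone.

Measured compounds:
compound 1 `Nc1cc(-c2ccc3cn[nH]c3c2)nc(N)n1`: 660000 nM
compound 2 `Nc1nccc(-c2cc(OCc3ccccc3)c3c(N)n[nH]c3c2)n1`: 85000 nM

In a physicochemical assay for solubility, read by LC-MS, in phosphate buffer, measured as kinetic solubility, with a stated time of 24 h, at 25 degrees C, at pH 7.4 (on this read-out higher numbers stand for higher solubility and lower numbers for lower solubility), compound 2 gives 85000 nM, the lower of the two numbers shown. Compound 1 gives 660000 nM in this assay, a gap between the two that lies beyond the usual scatter; the two compounds differ in more than one place, so only the two values themselves can be compared.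

Compound 3 `COc1cc(-c2ccnc(N)n2)cc2[nH]nc(N)c12` has not yet been measured. It differs from compound 2 by hydrogen in place of phenyl on a saturated chain carbon bound to an oxygen on an aromatic ring. A piece of the molecule leaves and nothing heavier than a hydrogen enters, so the step from compound 2 to compound 3 is expected to be larger than the scatter and upward, with the number expected to move toward the value compound 1 gives, 660000 nM. Compound 3 is therefore expected to give about 300000 nM in this assay, within a range of 100000 nM to 900000 nM, meaning an expected step of a 3.5-fold higher number from compound 2 to compound 3 (0.55 log units; beyond the scatter).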

Compound 3, solubility: > 100000 nM
Compound 3 ended at the assay's limit; the forecaster's own chance of this, stated with the estimate: 5%; the middle value lies beyond the limit too.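

In this assay compound 3 gives > 100000 nM, which is a limit of the assay and not a number. Read against that limit, the benzyloxy to methoxy change gives an at least 1.1-fold higher number from compound 2 to compound 3 (0.07 log units; that floor lies within the scatter), so the change at this place can be stated only as a floor, and that floor alone does not establish a rise. This is still the first comparison here between compounds that differ in one place, since compound 1 and compound 2 differ in more than one, and it is bounded by the following: the limit of > 100000 nM in this assay, at which 1 of the 3 values shown sits.

On these data alone, the true size of the step stays open while compound 3 rests on a limit. Also open, as far as these compounds go, is how a longer chain or a carboxylic acid in place of the phenyl, on the same saturated chain carbon, would read in this assay.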